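Working notes on a platelet inhibition series

The source may hold more compounds than are shown below. What is called first, only, known or untested is meant among the compounds shown, and "the series" means these compounds.

Measured so far:
compound 1 `CCOC(=O)c1ccc(-c2nn(Cc3ccccc3OC)c3ccccc23)cc1` gives > 10000 nM
compound 2 `CCOC(=O)c1ccc(-c2nn(Cc3cccc(OC)c3)c3ccccc23)cc1` gives > 10000 nM

In a functional assay on cells (Platelet, Homo sapiens) for inhibition (on this read-out higher numbers stand for weaker inhibition and lower numbers for stronger inhibition), compound 1 gives > 10000 nM, which is a limit of the assay and not a number. In this assay compound 2 gives > 10000 nM, also a limit. Among the measured compounds shown here, the only measured step, a step that the two limits leave unreadable from compound 1 to compound 2, cannot be read because the limit of > 10000 nM in this assay, at which 2 of the 2 values shown sit, applies to both ends. Compound 2 therefore stands at the limit with no number of its own.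

Compound 3 `CCOC(=O)c1ccc(-c2nn(C(C)C)c3ccccc23)cc1` differs from compound 2 by isopropyl in place of 3-methoxybenzyl on an aromatic nitrogen. For the measured compounds named here, no measured step bears on this change, and the one step in hand is unreadable, so there is no basis for expecting a direction. Compound 3 is expected to sit at or near the limit, estimated at 20000 nM in this assay, between 5000 nM and 80000 nM. The step expected from this estimate is a step that the limit leaves unreadable from compound 2 to compound 3.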

Compound 3, half-maximal inhibitory concentration: > 10000 nM
Compound 3 was reported as a limit; the forecaster's own chance of this, stated with the estimate: 80%; the middle value does not contradict the limit.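

The steps among compound 1, compound 2 and compound 3 cannot be read because all three values are one limit of the assay and not numbers: the limit of > 10000 nM in this assay, at which 3 of the 3 values shown sit. The compounds shown leave open whether any group on the aromatic nitrogen gives a measurable inhibition, and how large any difference between such groups would be.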